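This account rests on a few compounds, and the source may have more. Where it says the series, first, only, none or still open, it means among the compounds named here.

Within the data shown here, compound 1 `CCN(CC)S(=O)(=O)c1ccc(S(=O)(=O)N2CCC[C@@H](C(=O)NC3COC3)C2)cc1` sits at the weak end of the series: in a functional assay on MIA PaCa-2 cells (Homo sapiens) for inhibition, read by MTT assay, with a stated time of 7 days (on this read-out lower numbers stand for stronger inhibition and higher numbers for weaker inhibition), compound 1 gives 2340 nM, the highest of the three numbers so far. Compound 2 `CCN(CC)C(=O)c1ccc(S(=O)(=O)N2CCC[C@@H](C(=O)N3CCC(F)(F)CC3)C2)cc1` gives 70 nM and compound 3 `O=C([C@@H]1CCCN(S(=O)(=O)c2ccc(S(=O)(=O)N3CC[C@H](O)C3)cc2)C1)N1CCC(F)(F)CC1` gives 590 nM; both carry a cyclic tertiary amide rather than the secondary amide of compound 1, but each also differs from compound 1 in the group on the aromatic carbon, so their values cannot be split into an amide part and an aryl part.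

Compound 4 `CCN(CC)S(=O)(=O)c1ccc(S(=O)(=O)N2CCC[C@@H](C(=O)N3CC[C@@H](OC)C3)C2)cc1` is compound 1 with one change (3-methoxypyrrolidin-1-yl in place of (oxetan-3-yl)amino on a carbonyl carbon). Among the measured compounds shown here, the only single-point step measured, an 8.4-fold higher number from compound 2 to compound 3 (0.93 log units; beyond the scatter), concerns the aromatic substituent and leaves the amide untouched, so no measured step bears directly on this change. What the numbers of compound 2 and compound 3 do show is that a cyclic tertiary amide is compatible with lower values than compound 1 reaches. On that basis a moderate drop in the number is expected, with wide uncertainty because nothing isolates the amide change; the step expected is a 2.6-fold lower number from compound 1 to compound 4 (0.41 log units; beyond the scatter). Compound 4 is therefore estimated at 900 nM, with a range of 300 nM to 3000 nM.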

Compound 4, half-maximal inhibitory concentration: 3910 nM
Compound 4: middle estimate off by 4.3-fold (0.64 log units), on the low side, and the stated range ends below it.
By their numbers in this assay, from the lowest: compound 2; then compound 3; then compounds 1 and 4 (each within the scatter of the next).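

Among these compounds, exchanging (oxetan-3-yl)amino for 3-methoxypyrrolidin-1-yl on a carbonyl carbon gives a 1.7-fold higher number from compound 1 to compound 4 (0.22 log units; within the scatter) in this assay and is the first measured step at this position. With the group on the aromatic carbon held constant, the exchange removes the amide hydrogen, enlarges the ring from four-membered to five-membered and adds a defined stereocentre, yet the step stays within the scatter, so this pair gives no sign that a cyclic tertiary amide in itself lowers the number. No measurement at hand accounts for this result.

Still open, on these data alone, is how the 4,4-difluoropiperidin-1-yl amide shared by compound 2 and compound 3 would read with the aromatic substituent of compound 1 and compound 4, a pairing that would separate the amide contribution from the aryl contribution. Also open, as far as these compounds go, is whether the number at this carbonyl carbon would move with a different kind of group, such as a piperazin-1-yl ring or an open chain ending in a carboxylic acid.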